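Cyclising the ether on the amine-side chain

This account rests on a few compounds, and the source may have more. Where it says the series, first, only, none or still open, it means among the compounds named here.

For the measured compounds named here, compound 1 `CCO[C@@H](C)CN1CCC[C@H](Cn2c(-c3cccnc3C)nc3cn(-c4cccc(OC)c4)nc3c2=O)C1` and compound 2 `COc1cccc(-n2cc3nc(-c4ccccc4C)n(CC4CCCN(C(C)C)C4)c(=O)c3n2)c1` differ from each other in more than one place, so no single step between them is drawn. Going by the values given here, in an assay on HEK293 cells for displacement of a labelled ligand from growth hormone secretagogue receptor type 1 (Homo sapiens), with a stated time of 60 min (a higher number here means a weaker inhibitor, a lower number a stronger inhibitor), compound 1 gives 5 nM, the higher of the two numbers measured so far. Compound 2 gives 1.8 nM in this assay, a lower number, and that gap lies beyond the usual scatter.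

Compound 3 `COc1cccc(-n2cc3nc(-c4cccnc4C)n(C[C@H]4CCCN(CC5CCCCO5)C4)c(=O)c3n2)c1` is the next entry. Relative to compound 1 it carries oxan-2-yl in place of 1-ethoxyethyl on a saturated chain carbon bound to an amine nitrogen in a ring. Both groups are ethers; the entering one is closed into a ring. Among the compounds with values here, no step of this kind has been measured, so the expectation rests on compound 1 alone. The step is expected to be small, within the scatter, with no clear direction. Compound 3 is estimated at 5 nM in this assay, with a range from 1.5 nM to 15 nM. The step of no change at the digits printed from compound 1 to compound 3 (within the scatter) is expected to be close to none.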

Compound 3, half-maximal inhibitory concentration: 120 nM
Beside the measured number, compound 3's estimate is 24-fold (1.38 log units) below it; the measured number lies above the stated range.
By their numbers in this assay, from the lowest: compound 2; then compound 1; then compound 3.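

In this assay this position proves sensitive to the change: oxan-2-yl in place of 1-ethoxyethyl on a saturated chain carbon bound to an amine nitrogen in a ring gives a 24-fold higher number from compound 1 to compound 3 (1.38 log units; beyond the scatter) and so is far from a neutral exchange between two ethers. For the compounds shown here, compound 1 and compound 2 could not show this, as they differ in more than one place and no single step joined them. Nothing measured here bears on the reason for this step.

The entering oxan-2-yl has no defined stereocentre while the leaving 1-ethoxyethyl has one, so the share of ring closure in the step stays unresolved. Also open, as far as these compounds go, is how an oxolan-2-yl ring, an oxan-4-yl group or a longer open ether chain would read on this same carbon.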